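Methoxy to Methyl on the Chain of Compound 3

This account rests on a few compounds, and the source may have more. Where it says the series, first, only, none or still open, it means among the compounds named here.

Compound 1 `CCCCC(C)(C)[C@H](O)/C=C/[C@H]1CCC(=O)N1CCSc1nc(C(=O)O)cs1`: 8.4 nM
Compound 2 `O=C(O)c1csc(SCCN2C(=O)OC[C@@H]2/C=C/[C@@H](O)C2(CCc3ccccc3)CCC2)n1`: 27 nM
Compound 3 `COCCCC1([C@H](O)/C=C/[C@H]2COC(=O)N2CCSc2nc(C(=O)O)cs2)CCC1`: 25 nM

In an assay on isolated protein for agonist activity at prostaglandin E2 receptor EP3 subtype (Homo sapiens) (a higher number here means that more compound is needed for the effect, a lower number that less compound is needed), compound 3 stands second highest of the three numbers; compound 2 is nearest, and compound 1, with the lowest number, lies beyond the scatter from it. Compound 4 `CCCCC1([C@H](O)/C=C/[C@H]2COC(=O)N2CCSc2nc(C(=O)O)cs2)CCC1` differs from compound 3 as follows: methyl in place of methoxy on a saturated chain carbon, three bonds along the chain from a saturated ring carbon. Among the measured compounds shown here, the only measured step in this region, a 1.1-fold lower number from compound 2 to compound 3 (0.03 log units; within the scatter), swaps one chain end for another and stays within the scatter, so no measured step shows what removing the oxygen does. For the measured compounds named here, compound 1, carrying a plain alkyl chain, gives a lower number than compound 3, but no single-place step connects them. For compound 4 a modest step is expected, a 1.4-fold lower number from compound 3 to compound 4 (0.14 log units; within the scatter), with an estimate of 18 nM between 8 nM and 45 nM in this assay.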

Compound 4, half-maximal effective concentration: 3.9 nM
For compound 4 the middle estimate is 4.6-fold (0.66 log units) above the measured one, outside the stated range (below it).
By their numbers in this assay, from the lowest: compound 4; then compound 1; then compounds 3 and 2 (each within the scatter of the next).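

In this assay, butyl in place of 3-methoxypropyl gives a 6.4-fold lower number from compound 3 to compound 4 (0.81 log units; beyond the scatter), the first change at this position shown to go beyond the scatter. The earlier swap of chain ends had stayed within it. Replacing the phenyl end with ethyl gives a 6.9-fold lower number from compound 2 to compound 4 (0.84 log units; beyond the scatter), so the chain of compound 4 gives a lower number than both the methoxy-ended and phenyl-ended chains. No available evidence bears on the reason for this difference. The compounds shown leave open whether a longer chain, or an amine at the chain end, would keep the number this low.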